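The source may report more compounds than this note shows. Statements on the series, on what has been measured and on what is new or still open speak of the compounds shown alone.

Compound 3 `COc1cccc(CNCCCNc2ccnc3cc(-c4ccc(F)cc4)ccc23)c1O` sits level with compound 1 `COc1cccc(CNCCCNc2ccnc3cc(Cc4ccc(C#N)cc4)ccc23)c1O` in a physicochemical assay for acid dissociation, where compound 3 gives 9.47 and compound 1 gives 9.47; compound 2 `COc1cccc(CNCCCNc2ccnc3cc(Oc4cccc(N(C)C)c4)ccc23)c1O` gives 9.28 in this assay, and the step of a number 0.19 log units higher from compound 2 to compound 3 (within the scatter) keeps all three within the scatter of one another. Compound 4 `COc1cccc(CNCCCNc2ccnc3cc(C4CCCCC4)ccc23)c1O` differs from compound 3 by cyclohexyl in place of 4-fluorophenyl on an aromatic carbon. Going by the values given here, the steps that bear on this change are those at the same position: no change at the digits printed from compound 1 to compound 3 (within the scatter) and a number 0.19 log units lower from compound 1 to compound 2 (within the scatter), both within the scatter. The dissociating group lies far from the changed position, so no step beyond the scatter is expected, and the step of a number 0.02 log units lower from compound 3 to compound 4 (within the scatter) is estimated to be flat. For compound 4 the expected value in this assay is 9.45, with a range from 9.1 to 9.8.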

Compound 4, acid dissociation constant: 9.47
Beside the measured number, compound 4's estimate is 0.02 log units below it, and the stated range covers the measured number.
By their numbers in this assay, from the lowest: compounds 2, 1, 3 and 4 (each within the scatter of the next).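

In this assay, swapping the aromatic ring for a non-aromatic one at this position gives no change at the digits printed from compound 3 to compound 4 (within the scatter). The same holds against the groups with a linking atom, with no change at the digits printed from compound 1 to compound 4 (within the scatter) and a number 0.19 log units higher from compound 2 to compound 4 (within the scatter). Cyclohexyl therefore extends the set at this aromatic carbon to a non-aromatic ring of carbon only, and all four groups remain within the scatter of one another.

As far as these compounds go, whether an amine or a carboxylic acid on this aromatic carbon would move the number beyond the scatter stays open. No evidence on the reason for these flat steps is available.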